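The compounds below may be only part of what the source reports. "The series", "measured", "known", "first", "only" and "open" are said of these compounds alone.

Of the compounds shown here, three have so far been tested in an ADME assay on HeLa cells (Homo sapiens) for cytotoxicity, read by ATP content, with a stated time of 3 days (a lower number here means that less compound is tolerated, a higher number that more compound is tolerated), and none of them gave a finished number. Compound 1, with the structure `O=c1n(Cc2cc3cc(Cl)ccc3n2CCCCO)c2cnccc2n1C1CC1`, reached only a limit of > 50000 nM in this assay. Compound 2, with the structure `CC1(n2c(=O)n(Cc3cc4cc(Cl)ccc4n3CCCS(C)(=O)=O)c3cnccc32)CC1`, also stopped at a limit, > 50000 nM. Compound 3, with the structure `O=c1n(Cc2cc3ncccc3n2CCCCO)c2cnccc2n1C1CC1`, stopped at a limit of > 100000 nM. Compound 2 thus stands at the limit of > 50000 nM in this assay, at which 2 of the 3 values shown sit, whereas compound 3 sits at the limit of > 100000 nM in this assay, at which 1 of the 3 values shown sits; none of the three harmed the cells within the range tested.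

Compound 4, with the structure `CC(C)n1c(=O)n(Cc2cc3cc(Cl)ccc3n2CCCS(C)(=O)=O)c2cnccc21`, has not yet been measured. It differs from compound 2 in one place only: isopropyl in place of 1-methylcyclopropyl on an aromatic nitrogen. The remainder of the molecule is unchanged.

Among the compounds with values here, no step between two measured compounds is available here, so the data give no direct hint of how such a swap moves this assay. Given that the three measured values are all limits, the most likely outcome is that compound 4 stays at a limit as well, and the expected step from a step that the limit leaves unreadable from compound 2 to compound 4 is none beyond the scatter. Compound 4 is therefore estimated at 80000 nM, with a range from 35000 nM to 200000 nM, most probably reported again as a limit rather than a number.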

Compound 4, half-maximal cytotoxic concentration: > 50000 nM
Compound 4 gave a limit, no number (the forecaster's own chance of this, stated with the estimate: 85%); the middle value is on the limit's open side.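

Compound 2 and compound 4 each gave only a limit in this assay, and no step can be read for isopropyl in place of 1-methylcyclopropyl on the aromatic nitrogen. The compounds shown leave open at what concentration, if any, each would harm the cells, and whether this change alters that concentration at all.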